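Shortening the Ketone Chain on a Glutamate Receptor Modulator

The source may report more compounds than this note shows. Statements on the series, on what has been measured and on what is new or still open speak of the compounds shown alone.

Three measured compounds share a layout of two aromatic rings joined by a flexible chain, one ring carrying a ketone beside a hydroxyl and a methyl, the other carrying a carboxylic acid. Compound 1 is `CCC(=O)c1ccc(OCCCCOc2cc(C(=O)O)ccc2OC)c(C)c1O`, compound 2 is `CCCC(=O)c1ccc(OCCCCOc2cc(C(=O)O)ccc2OC)c(C)c1O` and compound 3 is `CCC(=O)c1ccc(OCCCCOc2ccc(C(=O)O)cc2C)c(C)c1O`. In an assay on HEK293 cells for positive allosteric modulation of metabotropic glutamate receptor 2 (Rattus norvegicus), read by thallium flux, with a stated time of 2.5 min (on this read-out lower numbers stand for an effect already at smaller amounts and higher numbers for an effect only at larger amounts of compound), compound 1 gives 162 nM, compound 2 gives 103 nM and compound 3 gives 82 nM. All three numbers lie within the usual scatter of one another, so none of these compounds can be called the strongest or the weakest.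

Compound 2 and compound 1 differ in one place: hydrogen in place of methyl on a saturated chain carbon, two bonds along the chain from a carbonyl carbon. The step of a 1.6-fold higher number from compound 2 to compound 1 (0.20 log units; within the scatter) is within the scatter. The difference between the cores of compound 2 and compound 3 is not broken down here.

Compound 4, `CC(=O)c1ccc(OCCCCOc2ccc(C(=O)O)cc2C)c(C)c1O`, is not yet measured. It differs from compound 3 by hydrogen in place of methyl on a saturated chain carbon bound to a carbonyl carbon. This is the same kind of change as that from compound 2 to compound 1, but not the same: in the earlier pair the carbon sits two bonds along the chain from a carbonyl carbon, whereas here it is bound to the carbonyl carbon.

Since the earlier removal of a methyl produced a step within the scatter, a similarly small step is expected here: a 1.6-fold higher number from compound 3 to compound 4 (0.20 log units; within the scatter), resting on the step of a 1.6-fold higher number from compound 2 to compound 1 (0.20 log units; within the scatter). Compound 4 is therefore estimated at 130 nM, with the likely range from 60 nM to 300 nM.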

Compound 4, half-maximal effective concentration: 50 nM
Compound 4: the middle estimate sits 2.6-fold (0.41 log units) above what was measured, and the stated range ends above it.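

Taking the methyl off the end of the propanoyl group of compound 3, which leaves an acetyl group, gives a 1.6-fold lower number from compound 3 to compound 4 (0.21 log units; within the scatter) in this assay. Setting this beside the earlier removal of a methyl from a ketone chain shows that the two results do not differ by more than the scatter allows: the same change on two cores in this assay, a 1.6-fold higher number (0.20 log units; within the scatter) from compound 2 to compound 1 and a 1.6-fold lower number (0.21 log units; within the scatter) from compound 3 to compound 4, 2.6-fold (0.41 log units) apart, within the scatter of two such steps. For the compounds shown here, on these two cores, then, trimming the ketone chain by one carbon leaves the number within the usual scatter, but this does not show that the change has a fixed size or direction, nor that the two cores respond differently, and with only two pairs, each trimming the chain at a different length, no wider rule can be drawn.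

The compounds shown leave open how the number behaves with an acetyl group on the core of compound 1, or with a ketone chain longer than that of compound 2, where a larger step might appear. They also leave open whether a branched isopropyl group or a cyclopropyl ring on the ketone would stay within the scatter in the same way.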